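This account rests on a few compounds, and the source may have more. Where it says the series, first, only, none or still open, it means among the compounds named here.

Compound 1 `COc1ncnc2c1c(-c1ccccc1)cn2[C@@H]1O[C@H](CO)[C@@H](O)[C@H]1O`: > 20000 nM
Compound 2 `CNc1ncnc2c1c(-c1ccccc1)cn2[C@@H]1O[C@H](CO)[C@@H](O)[C@H]1O`: > 20000 nM
Compound 3 `COc1ncnc2c1c(-c1cc3ccccc3o1)cn2[C@@H]1O[C@H](CO)[C@@H](O)[C@H]1O`: 17700 nM

These three compounds share a core and were tested in a functional assay on A549 cells (Homo sapiens), read by MTT assay, with a stated time of 72 h; a lower number here means a stronger inhibitor, a higher number a weaker inhibitor. For compound 1 the value > 20000 nM is a limit of the assay, not a number. For compound 2 the value > 20000 nM is likewise a limit. Within the data shown here, compound 3 gives the only number, 17700 nM. One change within the set is methylamino in place of methoxy on an aromatic carbon; the step it made, a step that the two limits leave unreadable from compound 1 to compound 2, cannot be read because both values sit at the limit of > 20000 nM in this assay, at which 2 of the 3 values shown sit. The two cores differ by 1-benzofuran-2-yl in place of phenyl on an aromatic carbon, a step of an at least 1.1-fold lower number from compound 1 to compound 3 (0.05 log units; that floor lies within the scatter). Compound 4 `CNc1ncnc2c1c(-c1cc3ccccc3o1)cn2[C@@H]1O[C@H](CO)[C@@H](O)[C@H]1O` is not yet measured in this assay; it differs from compound 3 by methylamino in place of methoxy on an aromatic carbon, the same change as between compound 1 and compound 2, at the same place. For compound 4 the expected step is a 1.1-fold lower number from compound 3 to compound 4 (0.04 log units; within the scatter), since compound 3 gives 17700 nM and the earlier step is unreadable. Compound 4 is expected to give 16000 nM, estimated between 4000 nM and 50000 nM.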

Compound 4, half-maximal inhibitory concentration: > 20000 nM
Compound 4 gave a limit, no number; the forecaster's own chance of this, stated with the estimate: 55%; middle value at least 1.2-fold (0.09 log units) from the limit.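

For compound 4 the result in this assay is a limit, not a number: > 20000 nM. On the core of compound 3, methylamino in place of methoxy gives an at least 1.1-fold higher number from compound 3 to compound 4 (0.05 log units; that floor lies within the scatter), which is only a floor on the step, so the series does not show whether the change acts alike on the two cores, or how large it is on either. The same change on the core of compound 1 and the step from compound 2 to compound 4 cannot be read, because both ends of each are limits: the limit of > 20000 nM in this assay, at which 3 of the 4 values shown sit.

From the compounds shown here alone, it remains open how far the value of compound 4 lies from that of compound 3. Going by these compounds, it also remains open whether another group on this aromatic carbon, such as a primary amine or dimethylamino, would give a readable number on either core.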